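The source may report more compounds than this note shows. Statements on the series, on what has been measured and on what is new or still open speak of the compounds shown alone.

Measured so far:
compound 1, `COc1cc2c(Oc3ccc(NC(=O)c4cc(-c5ccc(C)cc5)nc5ccccc45)cc3F)ccnc2cc1OCCCN1CCC(C)CC1`, 880 nM
compound 2, `COc1cccc(-c2cc(C(=O)Nc3ccc(Oc4ccnc5cc(OCCCN6CCCC6)c(OC)cc45)c(F)c3)c3ccccc3n2)c1`, 290 nM

In a functional assay on NCI-H460 cells (Homo sapiens) for cytotoxicity, read by MTT assay, with a stated time of 72 h (a higher number here means a weaker inhibitor, a lower number a stronger inhibitor), compound 2 gives 290 nM, the lower of the two numbers; compound 1 gives 880 nM, and the gap between the two lies beyond the usual scatter, so compound 2 stands as the stronger of the pair.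

Compound 3, `COc1cc2c(Oc3ccc(NC(=O)c4cc(-c5ccc(C)cc5)nc5ccccc45)cc3F)ccnc2cc1OCCCN1CCCC1`, is not yet measured. It carries 4-methylphenyl in place of 3-methoxyphenyl on an aromatic carbon. Compound 1 also carries 4-methylphenyl at this position but differs from compound 3 elsewhere, so no single-change comparison is available for the aryl swap alone. Compound 1 and compound 2 together hint that the 4-methylphenyl arrangement may sit somewhat weaker, though part of that gap may come from the other difference. A modest loss, perhaps at the edge of the scatter, is expected: a 1.9-fold higher number from compound 2 to compound 3 (0.28 log units; within the scatter). Compound 3 is thus estimated at 550 nM, with a range of 250 nM to 1200 nM.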

Compound 3, half-maximal inhibitory concentration: 240 nM
Beside the measured number, compound 3's estimate is 2.3-fold (0.36 log units) above it; measured number outside the range, below it.
By their numbers in this assay, from the lowest: compounds 3 and 2 (each within the scatter of the next); then compound 1.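

In this assay, putting 4-methylphenyl in place of 3-methoxyphenyl on the aromatic carbon next to the ring nitrogen gives a 1.2-fold lower number from compound 2 to compound 3 (0.08 log units; within the scatter) and so shows no measurable change at this position for this pair of aryl groups. Among these compounds, at the end of the chain, pyrrolidin-1-yl in place of 4-methylpiperidin-1-yl gives a 3.7-fold lower number from compound 1 to compound 3 (0.56 log units; beyond the scatter) and is the only step here that lies beyond the scatter, so this single change at the chain end matters more in these compounds than the aryl swap. Nothing measured here bears on why either step comes out as it does.

Going by these compounds, it remains open whether the chain-end step follows from the ring size or the methyl group, which a plain piperidin-1-yl would separate. On these data alone, it is also open whether the aryl position stays as flat with an unsubstituted phenyl or a phenyl carrying a carboxylic acid.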